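This account rests on a few compounds, and the source may have more. Where it says the series, first, only, none or still open, it means among the compounds named here.

Compound 2 `O=c1c2ccccc2[se]n1-c1nnc(-c2ccc(F)cc2)s1` gives 21100 nM in a functional assay on A549 cells (Homo sapiens) for antiproliferative activity, read by CCK-8 assay, with a stated time of 48 h (on this read-out higher numbers stand for weaker inhibition and lower numbers for stronger inhibition), the lowest of the two numbers seen so far. Compound 1 `O=c1c2ccccc2[se]n1-c1nnc(-c2ccc(Br)cc2)s1` gives 39100 nM in this assay, and the change in this assay is a 1.9-fold lower number from compound 1 to compound 2 (0.27 log units; within the scatter). Compound 3 `O=c1c2ccccc2[se]n1-c1nnc(-c2ccccc2Cl)s1` carries 2-chlorophenyl in place of 4-fluorophenyl on an aromatic carbon. Among the measured compounds shown here, only that one measured step bears on this change, a halogen swap that stayed within the scatter; the other part of the change, a chlorine at a new place on the ring, has no measured counterpart. The expected step from compound 2 to compound 3 is therefore a 1.2-fold higher number from compound 2 to compound 3 (0.07 log units; within the scatter). For compound 3 the estimate is 25000 nM, with a range from 8000 nM to 80000 nM.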

Compound 3, half-maximal inhibitory concentration: 10100 nM
The estimate for compound 3 lay 2.5-fold (0.39 log units) above the measured number; the measured number falls inside the stated range.
By their numbers in this assay, from the lowest: compound 3; then compounds 2 and 1 (each within the scatter of the next).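

In this assay, 2-chlorophenyl in place of 4-fluorophenyl gives a 2.1-fold lower number from compound 2 to compound 3 (0.32 log units; beyond the scatter), and in place of 4-bromophenyl it gives a 3.9-fold lower number from compound 1 to compound 3 (0.59 log units; beyond the scatter). This position on the shared core has therefore now produced modest steps beyond the scatter, which the earlier halogen swap did not. No available evidence explains these steps.

The change alters both the halogen and its place on the ring, so a 4-chlorophenyl or 2-fluorophenyl group would be needed to separate the two. Going by these compounds, how an amine or a carboxylic acid on this phenyl ring would behave also remains open.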